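The source may hold more compounds than are shown below. What is called first, only, known or untested is meant among the compounds shown, and "the series" means these compounds.

The measured compounds in this set are:

Compound 1 `C#CCOc1cc(N(CC)CC)ccc1/C=N/Cc1ccc(S(N)(=O)=O)cc1` with 62800 nM
Compound 2 `O=Cc1ccccc1OCc1cn(CCCOc2ccc3ccc(=O)oc3c2)nn1` with 18900 nM
Compound 3 `CCN(CC)c1ccc(C=O)c(OCc2cn(CCCOc3ccc4ccc(=O)oc4c3)nn2)c1` with 9030 nM

In a functional assay on HT-29 cells (Homo sapiens) for cytotoxicity, read by MTT assay, with a stated time of 24 h (on this read-out lower numbers stand for stronger inhibition and higher numbers for weaker inhibition), compound 2 gives 18900 nM, the second highest of the three numbers. Its nearest neighbour is compound 3, which in this assay gives 9030 nM; the step of a 2.1-fold lower number from compound 2 to compound 3 (0.32 log units; beyond the scatter) is a modest one and lies beyond the scatter. Furthest away is compound 1, which in this assay gives 62800 nM.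

Compound 4 `O=Cc1cc([N+](=O)[O-])ccc1OCc1cn(CCCOc2ccc3ccc(=O)oc3c2)nn1` is the next compound, not yet measured. It differs from compound 2 in one place: nitro in place of hydrogen on an aromatic carbon of the six-membered carbon ring, meta to the formyl group and para to the large group.

Going by the values given here, only one measured step bears on this change, and only loosely: the step of a 2.1-fold lower number from compound 2 to compound 3 (0.32 log units; beyond the scatter), where a different group, diethylamino, entered at what the two structures show to be the same aromatic carbon, and the number fell modestly. Among the compounds with values here, no step with nitro itself is available, so the expectation for compound 4 rests on compound 2 alone with wide bounds. Compound 4 is expected to give roughly 15000 nM in this assay, within a range from 5000 nM to 45000 nM, which is the expected step of a 1.3-fold lower number from compound 2 to compound 4 (0.10 log units; within the scatter) from compound 2 and lies within the scatter.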

Compound 4, half-maximal inhibitory concentration: 53600 nM
Estimate against measurement, compound 4: 3.6-fold (0.55 log units) below, outside the stated range (above it).
By their numbers in this assay, from the lowest: compound 3; then compound 2; then compounds 4 and 1 (each within the scatter of the next).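

Placing nitro on the aromatic carbon meta to the formyl group and para to the large group gives, in this assay, a 2.8-fold higher number from compound 2 to compound 4 (0.45 log units; beyond the scatter) and so provides the first direct reading of a substituent at this carbon, a modest weakening that lies beyond the scatter. This runs against a 2.1-fold lower number from compound 2 to compound 3 (0.32 log units; beyond the scatter) and shows that adding a group to this six-membered aromatic ring does not move the number in one direction across compounds 2, 3 and 4, although the structures show the diethylamino group of compound 3 on a different ring carbon, so the two steps change both the group and its place. Nothing measured here accounts for the rise in the number with nitro.

The compounds shown leave open whether the rise belongs to nitro itself or to any group at this carbon, a question that a methoxy group, an amine or a carboxylic acid there could test. They also leave open how nitro would read on the carbon that carries diethylamino in compound 3, which would separate the effect of the group from that of its place.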